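This account rests on a few compounds, and the source may have more. Where it says the series, first, only, none or still open, it means among the compounds named here.

Values in an ADME assay on MT4 cells (Homo sapiens) for cytotoxicity, read by MTT assay, with a stated time of 96 h; a lower number here means that less compound is tolerated, a higher number that more compound is tolerated:
- Compound 1 `CCC(=O)Oc1ccc2ccc(=O)oc2c1Cc1c(-c2ccccc2)[nH]c2ccccc12`: > 100000 nM (a limit)
- Compound 2 `CCC(=O)Oc1ccc2c(C)cc(=O)oc2c1Cc1c(-c2ccccc2)[nH]c2ccccc12`: 38000 nM
- Compound 3 `Cc1cc(=O)oc2c(CN(C)CC(=O)O)c(O)ccc12`: > 100000 nM (a limit)

Compound 1 has no exact number, only a limit of the assay. Compound 3 stands at that same limit, as the overall picture shows: the limit of > 100000 nM in this assay, at which 2 of the 3 values shown sit. On these data alone, the high end of the scale is therefore crowded, and the true position of compound 1 is unknown.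

The next compound is compound 4 `CCC(=O)Oc1ccc2ccc(=O)oc2c1Cc1c(C)[nH]c2ccccc12`. It differs from compound 1 by one exchange: methyl in place of phenyl on an aromatic carbon. A large ring leaves and a single carbon enters, on an aromatic carbon next to the ring nitrogen.

Among the compounds with values here, only one measured step bears on this, and only indirectly. It is an at least 2.6-fold lower number from compound 1 to compound 2 (0.42 log units; beyond the scatter), where methyl replaces hydrogen at another place on the shared core. Within the data shown here, that step shows that a small change can bring this family down from the limit, but no measured step touches the phenyl itself. In this assay, then, only a small move to a lower number is expected, or none beyond the scatter, and compound 4 may well sit at the limit too.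

For compound 4 the estimated value is 80000 nM, with an expected range from 35000 nM to 150000 nM.

The expected change is an at least 1.2-fold lower number from compound 1 to compound 4 (0.09 log units; that floor lies within the scatter).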

Compound 4, half-maximal cytotoxic concentration: 80000 nM
Beside the measured number, compound 4's estimate shows no gap at the digits printed; measured number inside the range.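

In this assay, within the data shown here, this is the first measured step that touches the phenyl itself: an at least 1.2-fold lower number from compound 1 to compound 4 (0.09 log units; that floor lies within the scatter). On these data alone, compound 1 gives > 100000 nM, which is a limit and not a number, so the true size of this step stays unknown and no change can be claimed from it. Compound 4 does show that a member of this family with a single carbon in place of the large ring still has a readable value high on the scale, yet that end of the scale remains crowded: the limit of > 100000 nM in this assay, at which 2 of the 4 values shown sit.

The compounds shown leave open whether a different group at this aromatic carbon, such as a butyl chain or a nitrile, would bring the number down beyond the scatter. They also leave open what the extra methyl of compound 2 would do when it is paired with the methyl of compound 4 rather than with the phenyl, since no compound shown carries both methyl groups.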